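Removing a chloro from compound 2: an expected small step

The source may hold more compounds than are shown below. What is called first, only, known or untested is meant among the compounds shown, and "the series" means these compounds.

Three close relatives of one purine-like series have been tested in a functional assay on PC-3 cells (Homo sapiens) for cytotoxicity, read by sulforhodamine B assay, with a stated time of 48 h; on this read-out lower numbers stand for stronger inhibition of growth and higher numbers for weaker inhibition of growth. Compound 1 `ClCc1ccccc1Cn1cnc2c(Cl)ncnc21` gives 10500 nM, compound 3 `ClCc1ccccc1Cn1cnc2ncnc(Cl)c21` gives 19100 nM, and compound 2 `ClCc1ccc(Cn2cnc3nc(Cl)nc(Cl)c32)cc1` gives 37200 nM. Compound 2 thus carries the highest number of the three: its gap to compound 3 lies within the scatter of this assay, while its gap to compound 1 lies beyond it. No two of these compounds differ in a single place, so none of these gaps can be tied to one change.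

Compound 4 `ClCc1ccc(Cn2cnc3ncnc(Cl)c32)cc1` has not yet been measured. It arises from compound 2 by a single change, (hydrogen in place of chloro on an aromatic carbon), that is, hydrogen in place of chloro on an aromatic carbon. The remaining chloro of compound 4 sits as it does in compound 3, whose value in this assay lies within the scatter of that of compound 2. For the measured compounds named here, no measured pair shows what loss of this chloro alone does. The step from compound 2 to compound 4 is therefore expected to stay within the scatter, with no direction claimed, as a 1.4-fold lower number from compound 2 to compound 4 (0.16 log units; within the scatter). Compound 4 is accordingly estimated at 26000 nM, with a range from 10000 nM to 65000 nM.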

Compound 4, concentration for total growth inhibition: 2950 nM
The estimate for compound 4 lay 8.8-fold (0.95 log units) above the measured number; the whole stated range lies above it.
By their numbers in this assay, from the lowest: compound 4; then compounds 1, 3 and 2 (each within the scatter of the next, the first and the last beyond it).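

In this assay, the aromatic carbon between two ring nitrogen atoms proves to be a position that matters: hydrogen in place of chloro there gives a 13-fold lower number from compound 2 to compound 4 (1.10 log units; beyond the scatter), a large step beyond the scatter. The earlier compounds shown here offered no pair that isolated this chloro, whereas this pair shows that its loss alone, with the rest of the structure unchanged, goes with stronger inhibition of growth. Nothing available here accounts for the size of this step or says what lies behind it.

As far as these compounds go, this position is now described only by the contrast between hydrogen and chloro in a single pair, so it remains open whether an amine, a methoxy group or a fluoro there would give a number nearer that of compound 4 or that of compound 2. From the compounds shown here alone, it also remains open whether the same change would give a step of similar size with the chloromethyl group placed as in compound 3, and what replacing the remaining chloro of compound 4 with an amine would do.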